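The source may hold more compounds than are shown below. What is called first, only, known or untested is meant among the compounds shown, and "the series" means these compounds.

Of the compounds shown here, three share a common core and have been measured in an in vitro functional assay on 1321-N1 cells for agonist activity at Free fatty acid receptor 1 (Homo sapiens), read by fluorescence, spectrophotometry and calcium flux; a higher number here means a larger maximal response, a lower number a smaller maximal response. Compound 1, `Cc1ccccc1-c1cc(C#Cc2ccc(CCC(=O)O)cc2)ccn1`, carries a 2-methylphenyl group on that core; in this assay compound 1 reaches 92%. Compound 2, `O=C(O)CCc1ccc(C#Cc2ncccc2[N+](=O)[O-])cc1`, gives 87%, a number that lies within the usual scatter of the value of compound 1, so the two cannot be told apart. Compound 3, `O=C(O)CCc1ccc(C#Cc2ccnc3cc(Cl)ccc23)cc1`, reaches 125%, a number beyond the scatter above compound 1. Among these three numbers compound 1 stands second highest, nearest to compound 2 and furthest from compound 3.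

Compound 4, `O=C(O)CCc1ccc(C#Cc2ccnc(-c3ccccc3)c2)cc1`, has not yet been measured. It differs from compound 1 in one place: hydrogen in place of methyl on an aromatic carbon. The methyl group that is lost sits on an aromatic carbon of a six-membered aromatic ring of carbon only, ortho to a large group, so the 2-methylphenyl of compound 1 becomes a plain phenyl in compound 4.

Going by the values given here, no measured pair in this set shows what removing a single methyl does here, so the expectation rests on the small size of the change. The step from compound 1 to compound 4 is expected to be small, a number 4 percentage points lower from compound 1 to compound 4 (within the scatter), most likely within the scatter. Compound 4 is therefore estimated to reach 88% in this assay, somewhere between 70% and 105%.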

Compound 4, largest response reached (reported as efficacy), in percent of the reference or control that the assay uses: 97%
For compound 4 the middle estimate is 9 percentage points below the measured one; the range from low to high includes it.
By their numbers in this assay, from the lowest: compounds 2, 1 and 4 (each within the scatter of the next); then compound 3.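

In this assay, the set now holds its first pair that differs in one place, and it reads a number 5 percentage points higher from compound 1 to compound 4 (within the scatter) on going from 2-methylphenyl to phenyl. At this position, on an aromatic carbon ortho to a large group, the methyl can therefore be exchanged for hydrogen with no change in maximal response that could be told from the usual scatter of repeated measurements, so the methyl is not needed to reach a response of this size. Nothing measured here offers a reason for this outcome.

This single pair covers only methyl and hydrogen at this one place, and it concerns only the largest response reached, not how much compound is needed to reach it. An ethyl group, a methoxy group, an amine or a carboxylic acid at the same place could show how much room this part of the molecule leaves before the maximal response moves beyond the scatter, and whether the answer depends on what the group is.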